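Enlarging the Ring on the Core Nitrogen

The source may hold more compounds than are shown below. What is called first, only, known or untested is meant among the compounds shown, and "the series" means these compounds.

Within the data shown here, compound 1 `CC(C)c1onc(-c2c(Cl)cccc2Cl)c1COc1ccc(-c2nc3cc(C(=O)O)ccc3n2C)cc1` and compound 2 `CC(C)c1onc(-c2c(Cl)cccc2Cl)c1COc1ccc(-c2nc3ccc(C(=O)O)cc3n2C2CC2)cc1` share a core but differ in more than one place, so no single step links them. In an assay on Huh-7 cells for agonist activity at Bile acid receptor (Homo sapiens), read by a luciferase reporter (on this read-out lower numbers stand for an effect already at smaller amounts and higher numbers for an effect only at larger amounts of compound), compound 1 gives 25.8 nM and compound 2 gives 16.5 nM. Compound 2 has the smaller of the two numbers, yet the gap to compound 1 lies within the scatter, so the two cannot be told apart. Compound 3 `CC(C)c1onc(-c2c(Cl)cccc2Cl)c1COc1ccc(-c2nc3ccc(C(=O)O)cc3n2C2CCC2)cc1` is compound 2 with one change: cyclobutyl in place of cyclopropyl on an aromatic nitrogen. Swapping cyclopropyl for cyclobutyl gives no reason to expect a step beyond the scatter, so the expected step is a 1.0-fold lower number from compound 2 to compound 3 (0.01 log units; within the scatter). Compound 3 is estimated at 16 nM in this assay, with a range from 6 nM to 45 nM.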

Compound 3, half-maximal effective concentration: 14.4 nM
Compound 3: middle estimate off by 1.1-fold (0.05 log units), on the high side, and the stated range covers the measured number.
By their numbers in this assay, from the lowest: compounds 3, 2 and 1 (each within the scatter of the next).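

Going from cyclopropyl to cyclobutyl on the aromatic nitrogen gives, in this assay, a 1.1-fold lower number from compound 2 to compound 3 (0.06 log units; within the scatter) and so offers the first reading of a single change at this position. Here the larger ring leaves the number within the scatter of the smaller one. Nothing measured here explains why the two rings read alike. Still open, on these data alone, is how this position responds to a larger ring such as cyclohexyl or to an open chain such as n-butyl. An amine on this nitrogen substituent also remains untested in the compounds shown.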